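Swapping the Chain End of Compound 1

The source may hold more compounds than are shown below. What is called first, only, known or untested is meant among the compounds shown, and "the series" means these compounds.

In a functional assay for inhibition, with Homo sapiens as the target (on this read-out higher numbers stand for weaker inhibition and lower numbers for stronger inhibition), compound 1 `O=C(O)CCCCCCCn1nc(-c2ccccc2)c(-c2ccccc2)c1-c1ccccc1` gives 3400 nM and is the only one of the three measured compounds with a number. Compound 2 `O=C(O)CCCCCCCCn1nc(-c2ccccc2)c(Cc2ccccc2)c1-c1ccccc1` stands at > 68000 nM in this assay which is a limit and not a number. Compound 3 `O=C(O)CCCCCCn1cc(-c2ccccc2)c(-c2ccccc2)n1` likewise stands at > 92000 nM in this assay which is again a limit.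

Compound 4 `O=C(O)C[S+]([O-])CCCCCCn1nc(-c2ccccc2)c(-c2ccccc2)c1-c1ccccc1` keeps the core of compound 1 and carries the change a group of 6 heavy atoms (2 carbon, 3 oxygen, 1 sulfur; no ring) in place of a group of 4 heavy atoms (2 carbon, 2 oxygen; no ring), on a saturated chain carbon, six bonds along the chain from an aromatic nitrogen in which the carboxymethyl group gives way to a group of 6 heavy atoms, on a saturated chain carbon, six bonds along the chain from an aromatic nitrogen.

Among the measured compounds shown here, no measured pair isolates a change of this kind, so the expectation rests on compound 1 at 3400 nM as its only numerical anchor. Weaker inhibition is expected for compound 4 with an estimated step of a 2.9-fold higher number from compound 1 to compound 4 (0.47 log units; beyond the scatter) that would lie beyond the scatter. Compound 4 is expected at 10000 nM with 2500 nM to 60000 nM as its estimated range.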

Compound 4, half-maximal inhibitory concentration: 6500 nM
Compound 4: middle estimate off by 1.5-fold (0.19 log units), on the high side; the range from low to high includes it.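

In this assay, among the compounds shown here, the first comparison between compounds that differ in one place is a 1.9-fold higher number from compound 1 to compound 4 (0.28 log units; within the scatter), with the assay's usual scatter covering the whole step. At this saturated chain carbon, six bonds along the chain from an aromatic nitrogen, the group of 6 heavy atoms (2 carbon, 3 oxygen, 1 sulfur) can therefore take the place of carboxymethyl and leave a number that cannot be told apart from that of compound 1, which no earlier comparison could show. Nothing in the data shown accounts for this result.

The compounds shown leave open whether a primary amide, a tetrazole or a sulfone at this place would also stay within the scatter of compound 1. They also leave open how a longer chain carrying the same group would read.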